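The source may hold more compounds than are shown below. What is called first, only, known or untested is meant among the compounds shown, and "the series" means these compounds.

Two compounds of the series have numbers in a functional assay on NFS-60 cells (Mus musculus) for antiproliferative activity, read by resazurin assay, with a stated time of 72 h; on this read-out higher numbers stand for weaker inhibition and lower numbers for stronger inhibition. Compound 1 `Cc1nc(-c2cnc(N3CCCCC3)[nH]c2=O)ccc1Oc1ccnc(-c2cnn(C)c2)c1` gives 30 nM in this assay, the lowest of the two numbers; compound 2 `Cc1nc(-c2cnc(NC3CC3)[nH]c2=O)ccc1Oc1ccnc(-c2cnn(C)c2)c1` gives 55 nM. Within the data shown here, the single measured step, a 1.8-fold higher number from compound 1 to compound 2 (0.26 log units; within the scatter), replaced the piperidin-1-yl with cyclopropylamino on the aromatic carbon and stayed within the scatter. Compound 3 `Cc1nc(-c2cnc(NC3CCCC3)[nH]c2=O)ccc1Oc1ccnc(-c2cnn(C)c2)c1` is the next compound to be measured in this assay. Relative to compound 1 it carries cyclopentylamino in place of piperidin-1-yl on an aromatic carbon. Among the measured compounds shown here, the one measured step bears on it directly: the same position, again a ring-bound amine exchanged for a secondary amino bearing a small carbocycle, and that step was within the scatter. A step of size a 1.2-fold higher number from compound 1 to compound 3 (0.07 log units; within the scatter) is therefore expected for compound 3, with no direction beyond the scatter. The expected value for compound 3 is 35 nM, with a range from 15 nM to 80 nM.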

Compound 3, half-maximal inhibitory concentration: 2.6 nM
Estimate against measurement, compound 3: 13-fold (1.13 log units) above; measured number outside the range, below it.
By their numbers in this assay, from the lowest: compound 3; then compounds 1 and 2 (each within the scatter of the next).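

In this assay this position, between two ring nitrogen atoms, proves far more sensitive than the first pair suggested: the two groups have the same atoms, joined differently, yet the change gives a 12-fold lower number from compound 1 to compound 3 (1.06 log units; beyond the scatter). The hydrogen on the amino nitrogen does not separate the compounds by itself, since cyclopropylamino also carries it and gives only a 1.8-fold higher number from compound 1 to compound 2 (0.26 log units; within the scatter), whereas the carbocycle on that nitrogen matters, with cyclopentyl in place of cyclopropyl giving a 21-fold lower number from compound 2 to compound 3 (1.33 log units; beyond the scatter). Nothing available on these compounds accounts for the gain.

Open, as far as these compounds go, is how the number follows ring size on that nitrogen, which cyclobutylamino and cyclohexylamino would bracket. Also open, from the compounds shown here alone, is whether the amino hydrogen is required alongside the cyclopentyl, which a methyl on that nitrogen would test.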